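The source may hold more compounds than are shown below. What is called first, only, known or untested is meant among the compounds shown, and "the series" means these compounds.

Compound 1 (`COc1ccc(C2=C(c3cc(OC)c(OC)c(OC)c3)C(=O)CC2O)cc1O`) gives < 1 ug/mL in an ADME assay on HT-29 cells (Homo sapiens) for cytotoxicity, read by MTT assay, with a stated time of 72 h (a higher number here means a weaker inhibitor, a lower number a stronger inhibitor), and that entry is a limit of the assay, not a number. For compound 2 (`COc1cc(C2=C(c3ccc(OCC(=O)O)cc3)C(O)CC2=O)cc(OC)c1OC`) the entry reads "not determined" (no result reported) and offers nothing to compare. Within the data shown here, compound 3 (`COc1ccc(C2=C(c3cc(OC)c(OC)c(OC)c3)C(=O)CC2O)cc1`) gives 15 ug/mL in this assay, which makes it the only compound here with an actual number.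

Compound 4 (`CCOC(=O)COc1ccc(C2=C(c3cc(OC)c(OC)c(OC)c3)C(=O)CC2O)cc1`) differs from compound 3 by one change (ethoxycarbonyl in place of hydrogen on a saturated chain carbon bound to an oxygen on an aromatic ring), ethoxycarbonyl in place of hydrogen on a saturated chain carbon bound to an oxygen on an aromatic ring, so that methoxy becomes (ethoxycarbonyl)methoxy.

Among the measured compounds shown here, only one measured step can serve as a guide, and it is large: an at least 15-fold higher number from compound 1 to compound 3 (1.17 log units; beyond the scatter) came with hydrogen in place of hydroxy on an aromatic carbon. That step swaps a different group, so its size cannot be carried over to the new change. It shows only that a single edit moved the number strongly between these two compounds, which argues for a wide range. With no measured match for the new change, the expected outcome is a 1.3-fold higher number from compound 3 to compound 4 (0.12 log units; within the scatter) in this assay, and no step beyond the scatter is expected in either direction. Expected for compound 4 is 20 ug/mL as the middle value, with 6 ug/mL and 60 ug/mL as the ends of the estimated range.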

Compound 4, half-maximal inhibitory concentration: > 100 ug/mL
Compound 4 was reported as a limit; the forecaster's own chance of this, stated with the estimate: 10%; middle value at least 5.0-fold (0.69 log units) from the limit.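

In this assay, among these compounds, the change from methoxy to (ethoxycarbonyl)methoxy gives an at least 6.6-fold higher number from compound 3 to compound 4 (0.82 log units; beyond the scatter), so this place on the shared core, which no earlier step had probed, clearly responds to what is attached there. Among the compounds shown here, the only earlier step, an at least 15-fold higher number from compound 1 to compound 3 (1.17 log units; beyond the scatter), involved hydrogen in place of hydroxy on an aromatic carbon, so two different single changes on this core have now each raised the number beyond the scatter. The entry for compound 4 is a limit of the assay, not a number: the limit of > 100 ug/mL in this assay, at which 1 of the 4 values shown sits.

Still open, as far as these compounds go, is whether the higher number goes with the ethoxycarbonyl group itself or with the longer chain as such, a question that a plain ethoxy or an amide in the same place would help to separate. Compound 2 carries a carboxylic acid on its chain but has no result, so it gives no sign of how a group other than the ester behaves here.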